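Dropping the fluoro from compound 1

A few compounds are considered here, and "the series" means these few. Any claim that something is new, unique, unknown or untested is made for them only; others in the source may bear on it.

Compound 1 `O=C(O)c1ccccc1-c1ccc(CCc2ncc(Cc3ccccc3F)[nH]2)cc1`: 177 nM
Compound 2 `CC(C)CCc1cnc(CCc2ccc(-c3ccccc3C(=O)O)cc2)[nH]1`: 119 nM

In an in vitro functional assay on cells for agonist activity at Bombesin receptor subtype-3 (Homo sapiens), read by luminescence and calcium flux (a lower number here means that less compound is needed, a higher number that more compound is needed for the effect), compound 1 gives 177 nM, and compound 2, carrying isobutyl in place of 2-fluorophenyl, gives 119 nM. Compound 1 thus holds the higher of the two numbers, yet the step of a 1.5-fold lower number from compound 1 to compound 2 (0.17 log units; within the scatter) lies within the scatter, so the two compounds cannot be told apart on these data. Compound 3 `O=C(O)c1ccccc1-c1ccc(CCc2ncc(Cc3ccccc3)[nH]2)cc1` differs from compound 1 by hydrogen in place of fluoro on an aromatic carbon. Among the compounds with values here, no measured step removes only this fluoro. Within the data shown here, the single step available, a 1.5-fold lower number from compound 1 to compound 2 (0.17 log units; within the scatter), exchanged the entire 2-fluorophenyl for isobutyl and still produced no change beyond the scatter; a smaller change at the same position gives no reason to expect more. Compound 3 is therefore expected to give about 200 nM, within a range of 80 nM to 500 nM, and the step of a 1.1-fold higher number from compound 1 to compound 3 (0.05 log units; within the scatter) is expected to stay within the scatter.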

Compound 3, half-maximal effective concentration: 205 nM
For compound 3 the middle estimate is 1.0-fold (0.01 log units) below the measured one; low and high end bracket the measured number.
By their numbers in this assay, from the lowest: compounds 2, 1 and 3 (each within the scatter of the next).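

In this assay, removing the fluoro alone leaves compound 1 and compound 3 indistinguishable (a 1.2-fold higher number from compound 1 to compound 3 (0.06 log units; within the scatter)), so on these data the 2-fluorobenzyl and the benzyl cannot be told apart at this position. The comparison of the plain phenyl with the isobutyl also stays within the scatter (a 1.7-fold higher number from compound 2 to compound 3 (0.24 log units; within the scatter)), so all three compounds, whether they end in 2-fluorophenyl, phenyl or isobutyl, read alike here. Nothing measured offers an explanation for this flat reading.

As far as these compounds go, it remains open whether any group at this position can move the number beyond the scatter, such as an amine on the phenyl or a longer chain in place of the isobutyl. The three compounds also leave open how the shared core and its carboxylic acid contribute.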